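A few compounds are considered here, and "the series" means these few. Any claim that something is new, unique, unknown or untested is made for them only; others in the source may bear on it.

Measured in a functional assay on HL-60 cells (Homo sapiens) for antiproliferative activity, with a stated time of 72 h; a higher number here means a weaker inhibitor, a lower number a stronger inhibitor:

- compound 1 `Nc1ncnn2c([C@@H]3O[C@H](CO)[C@@H](O)[C@H]3O)cc(C#Cc3cccs3)c12`: > 100000 nM
- compound 2 `Nc1ncnn2c([C@@H]3O[C@H](CO)[C@@H](O)[C@H]3O)cc(-c3ccc(F)cc3)c12`: 68300 nM
- compound 3 `Nc1ncnn2c([C@@H]3O[C@H](CO)[C@@H](O)[C@H]3O)cc(/C=C/c3ccccc3)c12`: 2000 nM

The value of compound 1 is a limit of the assay, not a number (the limit of > 100000 nM in this assay, at which 1 of the 3 values shown sits).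

Compound 3 has the lowest number of the three, and both steps leading to it lie beyond the scatter: an at least 50-fold lower number from compound 1 to compound 3 (1.69 log units; beyond the scatter) and a 34-fold lower number from compound 2 to compound 3 (1.53 log units; beyond the scatter). The next compound is compound 4 `Nc1ncnn2c([C@@H]3O[C@H](CO)[C@@H](O)[C@H]3O)cc(-c3ccsc3)c12`, in which thiophen-3-yl takes the place of 2-phenylethenyl on an aromatic carbon of the shared core: thiophen-3-yl in place of 2-phenylethenyl on an aromatic carbon.

Among the compounds with values here, two measured steps bear on this change. In compound 2, as in compound 4, an aromatic ring sits directly on the core, and a 34-fold lower number from compound 2 to compound 3 (1.53 log units; beyond the scatter) shows what 2-phenylethenyl gained over that arrangement. Within the data shown here, compound 1 is the only measured compound with a thiophene ring, though it is joined through an ethynyl link, and an at least 50-fold lower number from compound 1 to compound 3 (1.69 log units; beyond the scatter) also favours compound 3. Neither compound is a close match for compound 4, so the size of the step remains uncertain.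

In this assay, a large step towards a higher number is therefore expected: a 7.5-fold higher number from compound 3 to compound 4 (0.88 log units; beyond the scatter). For compound 4 the estimated value is 15000 nM, with an expected range from 1500 nM to 90000 nM.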

Compound 4, half-maximal inhibitory concentration: 37300 nM
The estimate for compound 4 lay 2.5-fold (0.40 log units) below the measured number; low and high end bracket the measured number.
By their numbers in this assay, from the lowest: compound 3; then compounds 4 and 2 (each within the scatter of the next). At a limit, above all of these: compound 1.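

In this assay, moving from 2-phenylethenyl to thiophen-3-yl at this position gives up most of the advantage of compound 3, with a 19-fold higher number from compound 3 to compound 4 (1.27 log units; beyond the scatter), and the new value shows that this holds for a second ring set directly on the core. The identity of that directly attached ring makes no difference that can be read here: thiophen-3-yl and 4-fluorophenyl lie within the scatter of each other, with a 1.8-fold lower number from compound 2 to compound 4 (0.26 log units; within the scatter), so compound 3 alone stands apart from them. A link between ring and core is not enough on its own, as compound 1 also carries one, and since compound 1 sits at a limit of the assay rather than a number, an at least 2.6-fold lower number from compound 1 to compound 4 (0.42 log units; beyond the scatter) gives only a floor: the limit of > 100000 nM in this assay, at which 1 of the 4 values shown sits.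

The compounds shown leave open whether the lower number of compound 3 goes with the double bond, with the phenyl ring at its end, or with the two together. From the compounds shown here alone, a 2-phenylethyl chain or a 2-(thiophen-3-yl)ethenyl group at this position would separate these, and the effect of an amine or a carboxylic acid on that phenyl ring also remains unknown.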